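Changing one aryl group on the weaker compound

The compounds below may be only part of what the source reports. "The series", "measured", "known", "first", "only" and "open" are said of these compounds alone.

In a functional assay on A-375 cells (Homo sapiens) for cytotoxicity, read by CCK-8 assay, with a stated time of 24 h (on this read-out lower numbers stand for stronger inhibition and higher numbers for weaker inhibition), compound 1 `COc1ccccc1Oc1c(N)nc(Cc2ccccc2)nc1OCCO` gives 200 nM, while compound 2 `COc1ccccc1Oc1c(N)nc(-c2ccc(F)cc2)nc1OCCO` gives 15900 nM, the higher of the two numbers and so the weaker inhibition. Compound 3 `COc1ccccc1Oc1c(N)nc(-c2cccc(Br)c2)nc1OCCO` differs from compound 2 in one place: 3-bromophenyl in place of 4-fluorophenyl on an aromatic carbon. Among the measured compounds shown here, the only measured step, an 80-fold higher number from compound 1 to compound 2 (1.90 log units; beyond the scatter), is large, but it replaced benzyl, so it says little about exchanging 4-fluorophenyl for 3-bromophenyl. A modest step towards a lower number is therefore expected, a 2.3-fold lower number from compound 2 to compound 3 (0.36 log units; beyond the scatter). For compound 3 the estimate is 7000 nM, with an expected range of 1500 nM to 25000 nM.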

Compound 3, half-maximal inhibitory concentration: 650 nM
Compound 3: middle estimate off by 11-fold (1.03 log units), on the high side; measured number below the stated range.
By their numbers in this assay, from the lowest: compound 1; then compound 3; then compound 2.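

Which aryl group sits on this carbon, between two ring nitrogen atoms, matters greatly: 3-bromophenyl in place of 4-fluorophenyl gives a 24-fold lower number from compound 2 to compound 3 (1.39 log units; beyond the scatter) and recovers most of what compound 2 lost. A directly attached ring can therefore come close to benzyl, although a 3.3-fold higher number from compound 1 to compound 3 (0.51 log units; beyond the scatter) still leaves compound 1 with the lower number. Nothing available here explains why these two aryl groups differ so much.

The compounds shown cannot separate the change of halogen from the change of its place on the ring, a question that 4-bromophenyl or 3-fluorophenyl would address. Also open, as far as these compounds go, is how a longer chain, such as 2-phenylethyl, would compare with benzyl.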